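A few compounds are considered here, and "the series" means these few. Any claim that something is new, unique, unknown or untested is made for them only; others in the source may bear on it.

Working notes on the series. Compound 1, `Oc1ccc(/C=N/c2ccc(OCc3ccccc3)cc2)c(O)c1`, is the reference member. In a functional assay, with a stated time of 30 min (a lower number here means a stronger inhibitor, a higher number a weaker inhibitor), compound 1 gives only a limit of the assay, > 200000 nM. Compound 2, `Oc1c(Br)cc(Br)cc1/C=N/c1ccc(OCc2ccccc2)cc1`, is the other measured member. In this assay compound 2 likewise reaches only the limit, > 200000 nM. Thus the limit of > 200000 nM in this assay, at which 2 of the 2 values shown sit: on the numbers shown, compound 1 stands at the limit with no measured value beneath it to set it against, and no single-place step between measured compounds can be drawn.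

Compound 3, `Oc1ccc(F)cc1/C=N/c1ccc(OCc2ccccc2)cc1`, is the unmeasured member that follows from compound 1. The change is 5-fluoro-2-hydroxyphenyl in place of 2,4-dihydroxyphenyl on a carbon with a double bond to nitrogen. The 2,4-dihydroxyphenyl gives way to 5-fluoro-2-hydroxyphenyl on the carbon with a double bond to nitrogen.

With compound 1 at the limit of > 200000 nM, the expectation for the step is no movement beyond the scatter: the expected step that the limit leaves unreadable from compound 1 to compound 3 is taken as essentially none. Most likely the assay again reports a limit rather than a number. Compound 3 is expected to give about 250000 nM, with a range from 50000 nM to 1000000 nM.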

Compound 3, half-maximal inhibitory concentration: > 200000 nM
Compound 3: no number, only a limit (the forecaster's own chance of this, stated with the estimate: 85%); the middle value is on the limit's open side.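

No step can be read between compound 1 and compound 3, as both end at a limit in this assay and not at a number: the limit of > 200000 nM in this assay, at which 3 of the 3 values shown sit. The compounds shown leave open whether any member of the series gives a measured value in this assay and how 5-fluoro-2-hydroxyphenyl compares with 2,4-dihydroxyphenyl on the shared core.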